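The source may report more compounds than this note shows. Statements on the series, on what has been measured and on what is new or still open speak of the compounds shown alone.

In a functional assay on HepG2 cells (Homo sapiens) for antiproliferative activity, read by MTT assay, with a stated time of 72 h (on this read-out higher numbers stand for weaker inhibition and lower numbers for stronger inhibition), compound 1 (`CCN(CC)CCCOc1cc2ncnc(Nc3ccc(C#N)cc3)c2cc1OC`) gives 59400 nM as the highest number of the three. Compound 2 (`COc1cc2c(Nc3ccc(C#N)cc3)ncnc2cc1OCCCN1CCCCC1`) gives 20700 nM and compound 3 (`COc1cc2c(Nc3ccc(C#N)cc3)ncnc2cc1OCCCN1CCC(N2CCCCC2)CC1`) gives 8840 nM on the same read-out. All three carry 4-cyanophenyl on a nitrogen on an aromatic ring and differ in the group on a saturated chain carbon. Compound 2 stands second highest of the three: a 2.9-fold lower number from compound 1 to compound 2 (0.46 log units; beyond the scatter) leads into it and a 2.3-fold lower number from compound 2 to compound 3 (0.37 log units; beyond the scatter) leads out of it.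

Compound 4 (`COc1cc2c(Nc3cccc(C#N)c3)ncnc2cc1OCCCN1CCCCC1`) is compared with compound 2 through 3-cyanophenyl in place of 4-cyanophenyl on a nitrogen on an aromatic ring and so has 3-cyanophenyl in place of 4-cyanophenyl on a nitrogen on an aromatic ring. Among the measured compounds shown here, no measured step touches that place. The measured steps serve only as a gauge of size. They are all modest, with a 6.7-fold lower number from compound 1 to compound 3 (0.83 log units; beyond the scatter) as the widest, and they give no direction for this change. In this assay the expectation therefore stays near compound 2 at 20700 nM with a wide margin. The estimated step is a 1.1-fold higher number from compound 2 to compound 4 (0.03 log units; within the scatter) with either direction open. Compound 4 is expected at 22000 nM within an estimated range of 9000 nM to 50000 nM overall.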

Compound 4, half-maximal inhibitory concentration: 29500 nM
For compound 4 the middle estimate is 1.3-fold (0.13 log units) below the measured one; the range from low to high includes it.
By their numbers in this assay, from the lowest: compound 3; then compounds 2, 4 and 1 (each within the scatter of the next, the first and the last beyond it).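

Placing 3-cyanophenyl in place of 4-cyanophenyl on a nitrogen on an aromatic ring gives the first reading at this place: in this assay there is a 1.4-fold higher number from compound 2 to compound 4 (0.15 log units; within the scatter) and so no separation between the two arrangements on this read-out. The earlier steps shown here all concerned the group on the saturated chain carbon and each lay beyond the scatter, while this exchange of two groups with the same atoms and the same counts, made with the piperidin-1-yl chain held fixed, does not. No supporting data accompany this result, so it stands as an observation without an explanation.

The compounds shown leave open whether 3-cyanophenyl would also read like 4-cyanophenyl on the 4-(piperidin-1-yl)piperidin-1-yl chain of compound 3, the lowest number in the series so far. They also leave open whether a different group on the same phenyl ring, such as an amine or a carboxylic acid in place of the nitrile, would separate from compound 2 in this assay or stay within the scatter of it.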